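The source may report more compounds than this note shows. Statements on the series, on what has been measured and on what is new or still open speak of the compounds shown alone.

Compound 1, `O=C(O)CCCCCCN1C(=O)CC[C@@H]1CCC(O)Cc1ccccc1`: > 3200 nM
Compound 2, `O=C(O)c1ccc(CCCN2C(=O)CCC2CCC(O)Cc2ccc(F)cc2)cc1`: > 3200 nM
Compound 3, `O=C(O)c1ccc(CCCN2C(=O)CC[C@@H]2CCC(O)Cc2ccc(Cl)cc2)s1`: > 3200 nM

All three compounds share a core and were tested in an assay on HEK293 cells for binding affinity to prostaglandin E2 receptor EP3 subtype (Homo sapiens); a higher number here means a weaker inhibitor, a lower number a stronger inhibitor. For compound 1 the result is only a limit of the assay, > 3200 nM. For compound 3 the result is likewise only a limit, > 3200 nM. Compound 2 stands in the same place: in this assay compound 2 gives > 3200 nM, which is a limit and not a number. So no compound here has a measured value, and no step between measured compounds can be read off; the whole picture is the limit of > 3200 nM in this assay, at which 3 of the 3 values shown sit.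

Compound 4, `O=C(O)c1ccc(CCCN2C(=O)CCC2CCC(O)Cc2cccc(Cl)c2)cc1`, is compound 2 with one change: 3-chlorophenyl in place of 4-fluorophenyl on a saturated chain carbon, two bonds along the chain from an oxygen on a saturated carbon. Nothing measured here speaks to what such a swap does in this assay. Given that compound 2 sits at the limit of > 3200 nM in this assay, at which 3 of the 3 values shown sit, the expected step from compound 2 to compound 4 is a step that the limit leaves unreadable from compound 2 to compound 4, that is, nothing beyond the usual scatter. Compound 4 is therefore estimated to give 5000 nM in this assay, with a range from 1500 nM to 20000 nM, and most likely the assay will again report only a limit.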

Compound 4, half-maximal inhibitory concentration: > 3200 nM
Compound 4: only a limit was reported; the forecaster's own chance of this, stated with the estimate: 75%; the middle value does not contradict the limit.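

Compound 2 and compound 4 both end at a limit of this assay and not at a number, so no step between them can be read: the limit of > 3200 nM in this assay, at which 4 of the 4 values shown sit.

Still open, going by these compounds, is what 3-chlorophenyl in place of 4-fluorophenyl does in this assay, and whether any compound with the shared core gives a measured number there.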